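Switching the pyrimidine substituent on compound 2's amine nitrogen

A few compounds are considered here, and "the series" means these few. Any claim that something is new, unique, unknown or untested is made for them only; others in the source may bear on it.

Measured so far:
- compound 1 `c1ccc(NCc2ccc(CNc3ncccn3)cc2)cc1`: 100%
- compound 2 `Fc1cnc(NCc2ccc(CNc3ncc(F)cn3)cc2)nc1`: 75%
- compound 3 `Clc1nc(Cl)nc(NCc2ccc(CNc3nc(Cl)nc(Cl)n3)cc2)n1`: 82%

In a functional assay on MDA-MB-231 cells for antagonist activity at C-X-C chemokine receptor type 4 (Homo sapiens), tested at 100 nM (on this read-out higher numbers stand for a stronger effect at the one concentration tested and lower numbers for a weaker effect), compound 2 gives the lowest of the three numbers. Its nearest neighbour is compound 3, whose number lies higher but within the usual scatter; compound 1 lies further above it, beyond the scatter.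

Compound 4 `CSc1ccnc(NCc2ccc(CNc3ncc(F)cn3)cc2)n1` has not yet been measured. It differs from compound 2 in one place: 4-(methylsulfanyl)pyrimidin-2-yl in place of 5-fluoropyrimidin-2-yl on an amine nitrogen. Going by the values given here, no measured pair in this set shows what such a change does in this assay, so no step beyond the scatter is expected in either direction. Compound 4 is therefore estimated at 80%, between 55% and 98%, which means an expected step of a number 5 percentage points higher from compound 2 to compound 4 (within the scatter).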

Compound 4, a percentage reported as inhibition, at one concentration (the size of the read-out at that concentration, not a potency): 92%
The estimate for compound 4 lay 12 percentage points below the measured number, within the range that was stated.
By their numbers in this assay, from the lowest: compounds 2, 3, 4 and 1 (each within the scatter of the next, the first and the last beyond it).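

In this assay, going by these compounds alone, 4-(methylsulfanyl)pyrimidin-2-yl in place of 5-fluoropyrimidin-2-yl on an amine nitrogen gives a number 17 percentage points higher from compound 2 to compound 4 (beyond the scatter), the first comparison here in which only one place changes. It shows that the number responds to the group on this amine nitrogen, and that the group carrying sulfur raises it. Nothing available here explains this step.

From the compounds shown here alone, whether a methoxy or a methylsulfonyl group would do the same in place of the methylsulfanyl stays open. So does the effect of the same swap on the other amine nitrogen.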